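Shifting the aryl group from dichlorophenyl to fluorophenyl

The compounds below may be only part of what the source reports. "The series", "measured", "known", "first", "only" and "open" are said of these compounds alone.

The compounds here share one core carrying a benzyl group on a ring nitrogen and an aryl group on a neighbouring aromatic carbon. Compound 1 `c1ccc(Cn2cc(-c3ccccc3)c3c2CCNC3)cc1` bears a plain phenyl there and in an assay on HEK293 cells for displacement of a labelled ligand from 5-hydroxytryptamine receptor 7 (Rattus norvegicus), with a stated time of 60 min (on this read-out lower numbers stand for stronger inhibition and higher numbers for weaker inhibition), compound 1 gives 220 nM. Going by the values given here, compound 2 `Clc1ccc(-c2cn(Cc3ccccc3)c3c2CNCC3)cc1Cl` carries a 3,4-dichlorophenyl instead; in this assay compound 2 gives 4470 nM, the second highest of the three numbers so far. Compound 3 `CC(C)(C)c1ccc(-c2cn(Cc3ccccc3)c3c2CNCC3)cc1` has a tert-butyl added to the phenyl, and in this assay compound 3 gives 10000 nM.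

Two steps are informative. Going a 20-fold higher number from compound 1 to compound 2 (1.31 log units; beyond the scatter), and going a 45-fold higher number from compound 1 to compound 3 (1.66 log units; beyond the scatter): both additions to the bare phenyl gave much weaker binding. Compound 4 `Fc1ccc(-c2cn(Cc3ccccc3)c3c2CNCC3)cc1` now takes the step (4-fluorophenyl in place of 3,4-dichlorophenyl on an aromatic carbon). This moves the aryl group back toward the unsubstituted phenyl of compound 1, with only a single fluorine remaining. Since compound 1 gave 220 nM and the chlorines in compound 2 coincided with a large loss, compound 4 is expected to bind more tightly than compound 2, by an 8.9-fold lower number from compound 2 to compound 4 (0.95 log units; beyond the scatter), though the fluorine may keep it short of compound 1. The estimate for compound 4 in this assay is 500 nM, with a range from 150 nM to 1600 nM.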

Compound 4, inhibition constant: 45 nM
Beside the measured number, compound 4's estimate is 11-fold (1.05 log units) above it; measured number below the stated range.
By their numbers in this assay, from the lowest: compound 4; then compound 1; then compound 2; then compound 3.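

In this assay, going by these compounds alone, the earlier compounds left the impression that anything added to the phenyl costs binding, but a 4.9-fold lower number from compound 1 to compound 4 (0.69 log units; beyond the scatter) is a gain that comes with a single fluoro group, so a substituted aryl group at this position can outdo the bare phenyl. Within the data shown here, the position is also more sensitive to what the aryl group carries than the earlier steps could show: a 99-fold lower number from compound 2 to compound 4 (2.00 log units; beyond the scatter) comes with 4-fluorophenyl in place of 3,4-dichlorophenyl, and a 220-fold lower number from compound 3 to compound 4 (2.35 log units; beyond the scatter) comes with fluoro in place of tert-butyl, both of them large steps. Nothing available here explains why these groups on the aryl ring differ so widely.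

Going by these compounds, compound 2 carries two chlorines, so it remains open whether a single chlorine would be accepted as well as the fluoro group of compound 4, or whether one chlorine is already enough for the loss. On these data alone, it is equally open how a methoxy group, a nitrile or an amine on the same aryl group would compare with the fluoro group.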